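The source may report more compounds than this note shows. Statements on the series, on what has been measured and on what is new or still open speak of the compounds shown alone.

Compound 1 `CCOC(=O)/C=C/c1ccncc1-c1ccc2c(cnn2C)c1` and compound 3 `CCOC(=O)/C=C/c1ccncc1-c1ccc2c(ccn2C)c1` share the ethyl ester side chain and differ in their cores; how the two cores differ is not broken down here. In a functional assay on MCF7 cells (Homo sapiens) for inhibition, read by sulforhodamine B assay, with a stated time of 72 h (a lower number here means a stronger inhibitor of growth, a higher number a weaker inhibitor of growth), compound 1 gives 7320 nM. In this assay compound 3 gives 8670 nM, a number within the scatter of that of compound 1. Compound 2 `Cn1ncc2cc(-c3cnccc3/C=C/C(=O)O)ccc21` carries the acid in place of the ester on the core of compound 1 (hydrogen in place of ethyl on an oxygen next to a carbonyl group). For compound 2 the read-out in this assay is only a limit, > 10000 nM. The step of an at least 1.3-fold higher number from compound 1 to compound 2 (0.13 log units; that floor lies within the scatter) therefore runs at least to the limit of the assay (the limit of > 10000 nM in this assay, at which 1 of the 3 values shown sits). Compound 4 `Cn1ccc2cc(-c3cnccc3/C=C/C(=O)O)ccc21` makes the same change on the core of compound 3 (hydrogen in place of ethyl on an oxygen next to a carbonyl group); the place described around the oxygen is the same in both pairs, so this is the same kind of change. Compound 3 starts from a number close to that of compound 1, and the step of an at least 1.3-fold higher number from compound 1 to compound 2 (0.13 log units; that floor lies within the scatter) is the measured guide for the same change. The step of a 1.5-fold higher number from compound 3 to compound 4 (0.18 log units; within the scatter) is therefore expected to be of the same kind. Compound 4 is estimated at 13000 nM in this assay, most likely again reported only as a limit.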

Compound 4, concentration for 50% growth inhibition: > 10000 nM
Compound 4 ended at the assay's limit; the forecaster's own chance of this, stated with the estimate: 65%; the middle value does not contradict the limit.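

On the core of compound 3, hydrogen in place of ethyl on an oxygen next to a carbonyl group (ethoxycarbonyl to carboxy) gives in this assay the step of an at least 1.1-fold higher number from compound 3 to compound 4 (0.06 log units; that floor lies within the scatter). The change thus carries over to the second core in one respect: compound 2 and compound 4 both end at a limit of the assay rather than at a number, and this is what the two acids share: the limit of > 10000 nM in this assay, at which 2 of the 4 values shown sit. It does not show that the change has the same size on both cores, nor, with both floors lying within the scatter, that either acid is truly a weaker inhibitor of growth than its ester: the same change on two cores in this assay, an at least 1.3-fold higher number (0.13 log units; that floor lies within the scatter) from compound 1 to compound 2 and an at least 1.1-fold higher number (0.06 log units; that floor lies within the scatter) from compound 3 to compound 4; the limit leaves it open whether they differ.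

The compounds shown leave open how far the two acids lie past the limit. They also leave open how this assay would respond on either core if a methyl ester, a primary amide or a longer chain on the ester oxygen took the place of the ethyl ester.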